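The source may report more compounds than this note shows. Statements on the series, on what has been measured and on what is new or still open speak of the compounds shown alone.

Compound 1 `CC1=CC[C@@H]([C@@](C)(O)CCCC(C)(C)NC(=S)N/N=C\c2ccccc2)CC1` gives 20900 nM in a functional assay on K562 cells (Homo sapiens) for cytotoxicity, read by sulforhodamine B assay; a lower number here means a stronger inhibitor of growth, a higher number a weaker inhibitor of growth.
Compound 2 `CC1=CC[C@@H]([C@@](C)(O)CCCC(C)(C)NC(=S)N/N=C\c2cccc(Cl)c2)CC1` gives 1060 nM in this assay.

For the measured compounds named here, compound 2 has the lower of the two numbers, and the single measured step, a 20-fold lower number from compound 1 to compound 2 (1.29 log units; beyond the scatter), separates it from compound 1. Compound 3 `CC1=CC[C@@H]([C@@](C)(O)CCCC(C)(C)NC(=S)N/N=C(/C)c2ccccc2)CC1` differs from compound 2 in one place: a group of 9 heavy atoms (8 carbon, 1 nitrogen; one six-membered aromatic ring of carbon only) in place of a group of 9 heavy atoms (7 carbon, 1 nitrogen, 1 chlorine; one six-membered aromatic ring of carbon only), on an amide-type nitrogen. The entering group therefore carries no chlorine, while the chlorine of compound 2 is exactly what the change from compound 1 to compound 2 introduced. That step is the only one that bears on this change, and it was large; reversing it is expected to raise the number again in this assay, although the entering group is not identical to the group in compound 1, so the size remains uncertain. For compound 3 the expected step is a 14-fold higher number from compound 2 to compound 3 (1.15 log units; beyond the scatter), giving an estimate of 15000 nM, within a range from 4000 nM to 50000 nM.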

Compound 3, concentration for total growth inhibition: 70 nM
The estimate for compound 3 lay 210-fold (2.33 log units) above the measured number; the measured number lies below the stated range.
By their numbers in this assay, from the lowest: compound 3; then compound 2; then compound 1.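

At the amide-type nitrogen, chlorine proves unnecessary for a low number in this assay. The entering group of 9 heavy atoms (8 carbon, 1 nitrogen) has no chlorine, yet it brings a 15-fold lower number from compound 2 to compound 3 (1.18 log units; beyond the scatter) and, measured against the unsubstituted group, a 300-fold lower number from compound 1 to compound 3 (2.48 log units; beyond the scatter). The chloro step is therefore not the only route to a lower number at this place, and the larger step here comes from altering the group that carries the aromatic ring, though nothing available explains why this group performs so well.

On these data alone, it remains open whether a chloro on the aromatic ring of compound 3 would lower the number further or add nothing. Also open, as far as these compounds go, is how a longer chain, such as ethyl, would compare with the entering group of compound 3.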